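Benzyl ring change in the sulfonamide-diamine series

The source may hold more compounds than are shown below. What is called first, only, known or untested is meant among the compounds shown, and "the series" means these compounds.

Compound 1 `O=S(=O)(NCCCNCc1ccc(Cl)c(Cl)c1)c1cc(C(F)(F)F)cc(C(F)(F)F)c1` carries a 3,4-dichlorobenzyl group on the amine and a three-carbon chain to the sulfonamide. In a functional assay on MIA PaCa-2 cells (Homo sapiens) for inhibition, read by MTT assay, with a stated time of 72 h (on this read-out higher numbers stand for weaker inhibition of growth and lower numbers for stronger inhibition of growth), compound 1 gives 2700 nM, the lowest number of the three measured compounds and beyond the scatter from both others. Compound 2 `COc1ccc(S(=O)(=O)NCCCCCCNCc2ccc(Br)cc2)cc1` gives 13000 nM and compound 3 `O=S(=O)(NCCCCCCNCc1ccc(Br)cc1)c1cc(Cl)cc(Cl)c1` gives 12000 nM; these two share a six-carbon chain and a 4-bromobenzyl group and differ only on the sulfonyl sulfur, where a 1.1-fold lower number from compound 2 to compound 3 (0.03 log units; within the scatter) lies within the scatter. Going by the values given here, neither is a single change away from compound 1, so their values show only that the longer-chain bromobenzyl pair sits well above compound 1.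

Compound 4 `O=S(=O)(NCCCNCc1ccccc1)c1cc(C(F)(F)F)cc(C(F)(F)F)c1` is the next step: phenyl in place of 3,4-dichlorophenyl on a saturated chain carbon bound to an amine nitrogen. Among the compounds with values here, the one measured step concerns the sulfonyl aryl, not the benzyl ring, so nothing measured bears directly on this change. The expected step is therefore a 2.2-fold higher number from compound 1 to compound 4 (0.35 log units; beyond the scatter), modest and upward, with wide uncertainty. Compound 4 is estimated at 6000 nM, between 2000 nM and 20000 nM.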

Compound 4, concentration for 50% growth inhibition: 11000 nM
The estimate for compound 4 lay 1.8-fold (0.26 log units) below the measured number, within the range that was stated.
By their numbers in this assay, from the lowest: compound 1; then compounds 4, 3 and 2 (each within the scatter of the next).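

In this assay, going by these compounds alone, phenyl in place of 3,4-dichlorophenyl on a saturated chain carbon bound to an amine nitrogen gives a 4.1-fold higher number from compound 1 to compound 4 (0.61 log units; beyond the scatter), the only measured step at this position. Unlike the change on the sulfonyl sulfur, a 1.1-fold lower number from compound 2 to compound 3 (0.03 log units; within the scatter), this one lies beyond the scatter, so growth inhibition in this pair responds to the benzyl ring while the rest of the structure stays fixed. The two chlorine atoms are the only atoms lost, but no available data explain the step.

On these data alone, whether one chlorine alone would keep the lower number remains open, as does the effect of a nitrile or a fluorine on the benzyl ring. Also open, as far as these compounds go, is whether the same step would appear on a longer chain.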